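Acyl variation on the pyrazoline series: compound 3 to compound 4

A few compounds are considered here, and "the series" means these few. Any claim that something is new, unique, unknown or untested is made for them only; others in the source may bear on it.

Three members of the series have been run in a functional assay on HCC1806 cells (Homo sapiens) for inhibition, read by sulforhodamine B assay, tested at 10 uM; a lower number here means less inhibition, a higher number more inhibition at the concentration tested (going by the name of the read-out). Compound 1 `COC(=O)CC(=O)N1N=C(c2ccc(N3CCN(C)CC3)cc2)CC1c1ccc(N(C)C)cc1` gives -8.3%, compound 2 `CC(=O)N1N=C(c2ccc(-n3ccnc3)cc2)CC1c1ccc(N(C)C)cc1` gives -9.7%, and compound 3 `CN(C)c1ccc(C2CC(c3ccc(-n4ccnc4)cc3)=NN2C(=O)CCCl)cc1` gives -5.2%. Compound 3 holds the highest number of the three, yet its distance to compound 1 and to compound 2 is within the scatter, so no order can be read among them. For the measured compounds named here, the single measured step, a number 4.5 percentage points higher from compound 2 to compound 3 (within the scatter), is within the scatter as well.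

Compound 4 `COC(=O)CC(=O)N1N=C(c2ccc(-n3ccnc3)cc2)CC1c1ccc(N(C)C)cc1` is not yet measured. It differs from compound 3 as follows: methoxycarbonyl in place of chloromethyl on a saturated chain carbon bound to a carbonyl carbon. Going by the values given here, no measured step covers this exchange directly; compound 1 is the only measured member carrying methoxycarbonyl on a saturated chain carbon bound to a carbonyl carbon, and its value sits among the others. On this basis compound 4 is expected to stay in the same flat band, with no step beyond the scatter, as a number 1.8 percentage points lower from compound 3 to compound 4 (within the scatter). Compound 4 is therefore estimated at -7%, in the range -20% to 8%.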

Compound 4, a percentage reported as inhibition, at one concentration (the size of the read-out at that concentration, not a potency): 2.1%
The estimate for compound 4 lay 9.1 percentage points below the measured number, within the range that was stated.
By their numbers in this assay, from the lowest: compounds 2, 1, 3 and 4 (each within the scatter of the next, the first and the last beyond it).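

In this assay, for the compounds shown here, methoxycarbonyl on a saturated chain carbon bound to a carbonyl carbon gives the first steps beyond the scatter: against hydrogen at this place, the change gives a number 11.8 percentage points higher from compound 2 to compound 4 (beyond the scatter) and stays modest, while against chloromethyl it gives a number 7.3 percentage points higher from compound 3 to compound 4 (within the scatter) and does not separate the two groups. With methoxycarbonyl held fixed, 1H-imidazol-1-yl in place of 4-methylpiperazin-1-yl on an aromatic carbon gives a number 10.4 percentage points higher from compound 1 to compound 4 (beyond the scatter) as a second modest step, so the series now responds to a change in either of two places.

From the compounds shown here alone, it remains open whether a carboxylic acid or a primary amine in place of methoxycarbonyl on this chain carbon would extend the step. Going by these compounds, it is also open whether a longer ester chain would do so. No measurement shown here accounts for these steps.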